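The compounds below may be only part of what the source reports. "The series", "measured", "known", "first", "only" and "open" are said of these compounds alone.

Measured in a functional assay on DU-145 cells (Homo sapiens) for inhibition, read by trypan blue exclusion, with a stated time of 96 h (a lower number here means a stronger inhibitor of growth, a higher number a weaker inhibitor of growth), so far:
- compound 1 (`Cc1ccc(CS/C(=C/c2ccc(O)cc2)C(=O)c2ccc(Cl)cc2)cc1`) gives 10000 nM
- compound 2 (`O=C(/C(=C\c1ccc(O)cc1)SCc1ccc(Cl)cc1)c1ccc(Cl)cc1`) gives 10000 nM
- compound 3 (`COc1ccc(OC)c(/C=C(/SCc2ccc(Cl)c(Cl)c2)C(=O)c2ccc(Cl)cc2)c1`) gives 10000 nM

Compound 3 stands level with compound 1 and compound 2 in this assay, and the numbers set none of the three apart. The move to compound 4 (`O=C(/C(=C\c1ccc(O)cc1)SCc1ccc(Cl)c(Cl)c1)c1ccc(Cl)cc1`) is a single exchange (4-hydroxyphenyl in place of 2,5-dimethoxyphenyl on a double-bonded chain carbon bound to a double-bonded chain carbon): 4-hydroxyphenyl in place of 2,5-dimethoxyphenyl on a double-bonded chain carbon bound to a double-bonded chain carbon. Going by the values given here, the one measured step (no change at the digits printed from compound 1 to compound 2 (within the scatter)) lies within the scatter, but it is chloro in place of methyl on an aromatic carbon, so it concerns another part of the structure. More relevant is that compound 2 (10000 nM) already carries the 4-hydroxyphenyl while compound 3 (10000 nM) carries the 2,5-dimethoxyphenyl, and their values are level, although the two also differ elsewhere. No step beyond the scatter is therefore expected in this assay, in either direction. The estimated step (a 1.1-fold lower number from compound 3 to compound 4 (0.05 log units; within the scatter)) stays within the scatter. Compound 4 is estimated at 9000 nM with an expected range of 3000 nM to 20000 nM in this measurement.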

Compound 4, concentration for 50% growth inhibition: 1000 nM
Beside the measured number, compound 4's estimate is 9.0-fold (0.95 log units) above it; the measured number lies below the stated range.
By their numbers in this assay, from the lowest: compound 4; then compounds 1, 2 and 3 (each within the scatter of the next).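

In this assay, going by these compounds alone, the exchange of 2,5-dimethoxyphenyl for 4-hydroxyphenyl on a double-bonded chain carbon bound to a double-bonded chain carbon gives a 10-fold lower number from compound 3 to compound 4 (1.00 log units; beyond the scatter) and is thereby the first step beyond the scatter. Chloro in place of hydrogen on an aromatic carbon gives a 10-fold lower number from compound 2 to compound 4 (1.00 log units; beyond the scatter) and 3,4-dichlorophenyl in place of 4-methylphenyl on a saturated chain carbon bound to a sulfur gives a 10-fold lower number from compound 1 to compound 4 (1.00 log units; beyond the scatter) so, among these four compounds, the lower number appears only where 4-hydroxyphenyl and 3,4-dichlorophenyl stand together. No measurement at hand accounts for this pairing.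

The compounds shown leave open whether the hydroxyl itself matters, as a methoxy or an amine in its place on that phenyl would test. They also leave open whether bromo could stand in for the added chloro.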